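Methoxy for trifluoromethyl: cytotoxicity at the assay limit

The source may report more compounds than this note shows. Statements on the series, on what has been measured and on what is new or still open speak of the compounds shown alone.

Measured in an ADME assay on MDBK cells (Bos taurus) for cytotoxicity, read by MTT assay; on this read-out lower numbers stand for higher toxicity in this test and higher numbers for lower toxicity in this test:
- Compound 1 `OC[C@@H]1[C@@H](O)[C@H](O)[C@@H](O)CN1CCCCCCOc1ccc(OC(F)(F)F)cc1`: > 500000 nM
- Compound 2 `OC[C@@H]1[C@@H](O)[C@H](O)[C@@H](O)CN1CCCCCCOc1ccc(C(F)(F)F)cc1`: > 500000 nM

Compound 2 stands at > 500000 nM, which is a limit of the assay and not a number. Compound 1 likewise gives only a limit. Compound 3 `COc1ccc(OCCCCCCN2C[C@H](O)[C@@H](O)[C@H](O)[C@H]2CO)cc1` differs from compound 2 by one change, methoxy in place of trifluoromethyl on an aromatic carbon. For the measured compounds named here, the only measured step that bears on it is a step that the two limits leave unreadable from compound 1 to compound 2, which also exchanges a group on an aromatic carbon. No size can be taken from that step. Going by the values given here, the sole guide is the limit of > 500000 nM in this assay, at which 2 of the 2 values shown sit, so no step beyond the scatter is expected in this assay, and another limit is the likeliest report. The expected step is a number no higher from compound 2 to compound 3 (the limit leaves the size open). Compound 3 is estimated at 500000 nM, with an expected range of 200000 nM to 1000000 nM.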

Compound 3, half-maximal cytotoxic concentration: > 500000 nM
Compound 3 was reported as a limit; the forecaster's own chance of this, stated with the estimate: 85%; the middle value sits exactly at the limit.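

In this assay compound 3 gives > 500000 nM, a limit of the assay and not a number. For the compounds shown here, no step among compound 1, compound 2 and compound 3 can be read. The compounds shown leave open whether trifluoromethoxy, trifluoromethyl and methoxy differ at all in this read-out: the limit of > 500000 nM in this assay, at which 3 of the 3 values shown sit.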